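A Fluorine Added to the Anilino Group

This account rests on a few compounds, and the source may have more. Where it says the series, first, only, none or still open, it means among the compounds named here.

Among three measured compounds, compound 1 `Cc1ccc(Oc2ccc(/C=N/NC(=S)Nc3ccccc3)cc2)cc1` stands second highest in a physicochemical assay for lipophilicity, in phosphate buffer, measured as octanol-water partition, with a stated time of 24 h (on this read-out higher numbers stand for higher lipophilicity and lower numbers for lower lipophilicity), giving 5.39. Compound 2 `S=C(N/N=C/c1ccc(Oc2ccc(Cl)cc2)cc1)Nc1ccccc1` gives 5.52, a change of a number 0.13 log units higher from compound 1 to compound 2 (within the scatter). Compound 3 `S=C(N/N=C/c1ccc(Oc2ccccc2)cc1)Nc1ccccc1` gives 4.9, a change of a number 0.49 log units lower from compound 1 to compound 3 (beyond the scatter). The step of a number 0.62 log units lower from compound 2 to compound 3 (beyond the scatter) also concerns a halogen on an aromatic carbon and is the closest guide, though it involves chlorine at another place. Compound 4 `Cc1ccc(Oc2ccc(/C=N/NC(=S)Nc3ccc(F)cc3)cc2)cc1` differs from compound 1 by fluoro in place of hydrogen on an aromatic carbon. A single fluorine is expected to move this assay only slightly upward, by a number 0.16 log units higher from compound 1 to compound 4 (within the scatter), a step likely within the scatter. Compound 4 is therefore estimated at 5.55, in the range 5.25 to 5.85.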

Compound 4, partition coefficient: 5.48
Compound 4: the middle estimate sits 0.07 log units above what was measured; the measured number falls inside the stated range.
By their numbers in this assay, from the lowest: compound 3; then compounds 1, 4 and 2 (each within the scatter of the next).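

Compound 4 is the first shown with a change on the anilino group, and in this assay placing fluoro there gives a number 0.09 log units higher from compound 1 to compound 4 (within the scatter). At this place, para to a large group, a single fluoro therefore leaves the read-out within the scatter, whereas a number 0.49 log units lower from compound 1 to compound 3 (beyond the scatter) at another place lies beyond it. Nothing available explains this small step. Still open, going by these compounds, is whether an amine or a carboxylic acid at this same place would move the number beyond the scatter.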